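Moving the chloro group on a biaryl nitrile

The source may report more compounds than this note shows. Statements on the series, on what has been measured and on what is new or still open speak of the compounds shown alone.

Compound 1 `N#Cc1ccc(Nc2nccc(Oc3ccc(-c4ccc(C#N)cc4Cl)cc3Cl)n2)cc1`: > 273000 nM
Compound 2 `Cc1cc(C#N)ccc1-c1ccc(Oc2ccnc(Nc3ccc(C#N)cc3)n2)c(F)c1`: > 296000 nM

Both compounds were tested in a functional assay on MT4 cells (Homo sapiens) for cytotoxicity, read by MTT assay, with a stated time of 5 days; on this read-out lower numbers stand for higher toxicity in this test and higher numbers for lower toxicity in this test. For compound 1 the value > 273000 nM is a limit of the test rather than a number. For compound 2 the value > 296000 nM is likewise a limit. Compound 1 therefore stands at the ceiling of what this assay can report, as shown by the limit of > 273000 nM in this assay, at which 1 of the 2 values shown sits, and the second compound sits at its own ceiling, (the limit of > 296000 nM in this assay, at which 1 of the 2 values shown sits). Among the compounds with values here, no step between two measured compounds is available here.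

Compound 3 `N#Cc1ccc(Nc2nccc(Oc3ccc(-c4ccc(C#N)c(Cl)c4)cc3Cl)n2)cc1` differs from compound 1 only in how the same atoms are joined: 3-chloro-4-cyanophenyl in place of 2-chloro-4-cyanophenyl on an aromatic carbon. The new group sits on an aromatic carbon of a six-membered aromatic ring of carbon only, meta to a chloro group and para to a large group. Within the data shown here, with no measured step to lean on, and both known values at a limit, no change beyond the scatter is expected in this assay. Compound 3 is expected to give about 280000 nM, within 100000 nM to 600000 nM, which is an estimated step that the limit leaves unreadable from compound 1 to compound 3, most likely reported again as a limit.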

Compound 3, half-maximal cytotoxic concentration: 14900 nM
Estimate against measurement, compound 3: 19-fold (1.27 log units) above; measured number below the stated range.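

In this assay, the change shows an at least 18-fold lower number from compound 1 to compound 3 (1.26 log units; beyond the scatter), so the place of the chloro group on this outer ring matters, and compound 3 is the only one of the three with a measured number rather than a limit. The groups that leave and enter have the same counts of heavy atoms and hydrogen-bond acceptors and the same lack of net charge, so those counts do not separate the two compounds, and only how the atoms are joined does. The true size of this step remains unknown because compound 1 gives only a limit, which makes the printed step a minimum: the limit of > 273000 nM in this assay, at which 1 of the 3 values shown sits.

The compounds shown leave open whether the lower number in this assay depends on chloro itself at this place, or would also appear with another group there, such as a methoxy group or an amine. They give no reason for the change, and compound 2 differs from compound 3 in more than one place, so it cannot settle the question.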